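Series notes: diethoxyphenyl to phenyl on two cores

The compounds below may be only part of what the source reports. "The series", "measured", "known", "first", "only" and "open" are said of these compounds alone.

Compound 1 `CCOc1ccc(C=C(C(=O)/C=C/c2ccc(O)c(OC)c2)C(=O)/C=C/c2ccc(O)c(OC)c2)cc1OCC` and compound 3 `CCOc1cc(/C=C/C(=O)C(=Cc2ccc(OCC)c(OCC)c2)C(=O)/C=C/c2ccc(O)c(OCC)c2)ccc1O` are both read in a functional assay, read by spectrophotometry, with a stated time of 5 min; on this read-out lower numbers stand for stronger inhibition and higher numbers for weaker inhibition; compound 1 gives 73000000 nM and compound 3 gives 61600000 nM. The difference between the two cores is not broken down here. Compound 2 `COc1cc(/C=C/C(=O)C(=Cc2ccccc2)C(=O)/C=C/c2ccc(O)c(OC)c2)ccc1O` carries phenyl in place of 3,4-diethoxyphenyl on a double-bonded chain carbon bound to a double-bonded chain carbon relative to compound 1, and in this assay compound 2 gives 84400000 nM; the step is a 1.2-fold higher number from compound 1 to compound 2 (0.06 log units; within the scatter). Compound 4 `CCOc1cc(/C=C/C(=O)C(=Cc2ccccc2)C(=O)/C=C/c2ccc(O)c(OCC)c2)ccc1O` is not yet measured; it carries phenyl in place of 3,4-diethoxyphenyl on a double-bonded chain carbon bound to a double-bonded chain carbon relative to compound 3, the same change at the same place. The expectation for compound 4 is a similar step, a 1.2-fold higher number from compound 3 to compound 4 (0.08 log units; within the scatter), because a 1.2-fold higher number from compound 1 to compound 2 (0.06 log units; within the scatter) stayed within the scatter. Compound 4 is therefore estimated in this assay at 74000000 nM, with a likely range from 40000000 nM to 140000000 nM.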

Compound 4, half-maximal inhibitory concentration: 91400000 nM
For compound 4 the middle estimate is 1.2-fold (0.09 log units) below the measured one; the range from low to high includes it.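

In this assay, phenyl in place of 3,4-diethoxyphenyl on the second core gives a 1.5-fold higher number from compound 3 to compound 4 (0.17 log units; within the scatter), and the two cores agree on this change: the same change on two cores in this assay, a 1.2-fold higher number (0.06 log units; within the scatter) from compound 1 to compound 2 and a 1.5-fold higher number (0.17 log units; within the scatter) from compound 3 to compound 4, 1.3-fold (0.11 log units) apart, within the scatter of two such steps. Between these two cores the change therefore carries over, in the sense that it stays within the scatter on both. This does not show that the change has a real effect on either core, and two cores set no rule for the wider series.

Still open, as far as these compounds go, is whether another group at this place, such as an amine, a carboxylic acid or a longer alkoxy chain on the phenyl, would give a step beyond the scatter. The same question stands for any core other than these two.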